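Methyl in place of hydrogen: cytotoxicity notes

The compounds below may be only part of what the source reports. "The series", "measured", "known", "first", "only" and "open" are said of these compounds alone.

Measured so far:
compound 1 `C/C(=N\NC(=O)c1cccc2ccccc12)c1ccccc1O` — > 200000 nM
compound 2 `C/C(=N\NC(=O)c1cnccn1)c1ccccc1O` — 41200 nM
compound 3 `CC/C(=N\NC(=O)c1cccc2ccccc12)c1ccccc1O` — > 200000 nM

In a toxicity assay (H9c2 cells) for cytotoxicity, with Rattus norvegicus as the target, read by neutral red uptake, with a stated time of 72 h (a higher number here means a weaker inhibitor, a lower number a stronger inhibitor), compound 1 gives only a limit, > 200000 nM. Compound 3 also gives only a limit, > 200000 nM. Among the compounds with values here, compound 2 gives 41200 nM, the one number in the set. The change from compound 1 to compound 3 is methyl in place of hydrogen on a saturated chain carbon bound to a carbon with a double bond to nitrogen, and the step that the two limits leave unreadable from compound 1 to compound 3 cannot be sized because of the limit of > 200000 nM in this assay, at which 2 of the 3 values shown sit. How the core of compound 2 differs from that of compound 1 is not broken down here.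

Compound 4 `CC/C(=N\NC(=O)c1cnccn1)c1ccccc1O` carries the same change on the core of compound 2, (methyl in place of hydrogen on a saturated chain carbon bound to a carbon with a double bond to nitrogen). With no readable size for the earlier step, the expected step of a 1.2-fold higher number from compound 2 to compound 4 (0.08 log units; within the scatter) is taken as small. Compound 4 is therefore expected near 50000 nM, within 18000 nM to 160000 nM.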

Compound 4, half-maximal inhibitory concentration: > 100000 nM
Compound 4: only a limit was reported; the forecaster's own chance of this, stated with the estimate: 20%; middle value at least 2.0-fold (0.30 log units) away from the limit.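

In this assay the change from hydrogen to methyl reads as an at least 2.4-fold higher number from compound 2 to compound 4 (0.38 log units; beyond the scatter) and so gives a weaker result on this core. On these data alone, compound 4 gives > 100000 nM as a limit and not a number, so the full size of this step stays unknown. The same change on the core of compound 1 cannot be read, so these compounds neither show nor rule out that the effect carries from one core to the other, because both of its values are limits: the limit of > 200000 nM in this assay, at which 2 of the 4 values shown sit.

As far as these compounds go, whether a longer chain such as propyl at the same place would shift the value on the core of compound 2 stays open. From the compounds shown here alone, the effect of an amine there is equally open.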